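The compounds below may be only part of what the source reports. "The series", "measured", "known", "first", "only" and "open" are said of these compounds alone.

Compound 2 `Cc1c(OCCCCOCOc2ccc(C(=O)O)cc2)ccc(C(=O)CC2CCCC2)c1O` was tested in an ADME assay (liver) for metabolic stability, with Liver microsome (Rattus norvegicus) as the target, read by LC-MS, using microsomes and NADPH, with stated times of 5 min and 60 min, tested at 4 uM (on this read-out lower numbers stand for a less stable compound and higher numbers for a more stable compound), where compound 2 gives 31%. Among the two compounds measured in this way, that is the lowest number. Among the measured compounds shown here, the only comparison is compound 1 `Cc1c(OCCCCOc2ccc(C(=O)O)cc2)ccc(C(=O)CC(C)C)c1O`, and in this assay compound 1 gives 66%, a number that lies above compound 2 by more than the usual scatter; the two compounds differ in more than one place, so this gap cannot be tied to a single change.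

The next compound to be measured is compound 3 `Cc1c(OCCCCOc2ccc(C(=O)O)cc2F)ccc(C(=O)CC2CCCC2)c1O`. Against compound 2, the change is 4-carboxy-2-fluorophenyl in place of (4-carboxyphenoxy)methyl on an oxygen on a saturated carbon. For the measured compounds named here, no single-change step between two measured compounds is available to guide this, so the expectation rests on compound 1 and compound 2 alone. The step from compound 2 to compound 3 is expected to be a number 19 percentage points higher from compound 2 to compound 3 (beyond the scatter), upward and beyond the scatter, since compound 3 resembles compound 1, which gives 66%, more closely in the linking chain. For compound 3 in this assay, the estimate is 50%, with a range from 25% to 75%.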

Compound 3, percent of the compound remaining: 66%
For compound 3 the middle estimate is 16 percentage points below the measured one; the measured number falls inside the stated range.
By their numbers in this assay, from the lowest: compound 2; then compounds 1 and 3 (each within the scatter of the next).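

Among the compounds shown here, with the rest of the molecule held constant, this is the first comparison here that isolates a single site: in this assay, exchanging the one group that differs gives a number 35 percentage points higher from compound 2 to compound 3 (beyond the scatter). The group at this place therefore has a large bearing on the percent of compound remaining, something the earlier pair could not show, as its two members differ in more than one place. No measurement shown here explains how this swap raises the number, so the size of the step stands as an observation without a cause.

The swap also alters two things at once, removing the oxygen-linked methyl piece and bringing in a fluorine, so the compounds shown cannot assign the step to either alteration alone. Also open, from the compounds shown here alone, is how this place would respond to a chlorine in place of that fluorine, or to a longer chain joining the oxygen to the carboxyphenyl ring.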